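Adding One Methyl to Compound 3

A few compounds are considered here, and "the series" means these few. Any claim that something is new, unique, unknown or untested is made for them only; others in the source may bear on it.

Of the compounds shown here, three built on a shared core have been tested so far in an ADME assay on Vero 76 cells (Chlorocebus sabaeus) for cytotoxicity, read by MTT assay, with a stated time of 96 h; on this read-out lower numbers stand for higher toxicity in this test and higher numbers for lower toxicity in this test. Compound 1 `NS(=O)(=O)c1ccc(N2N=C(c3ccccc3)CC2c2ccccc2Cl)cc1` gives 26000 nM. Compound 3 `NS(=O)(=O)c1ccc(N2N=C(c3ccc(Oc4ccccc4)cc3)CC2c2ccccc2)cc1` gives 85000 nM, the higher of the two exact numbers, and the gap between these two values lies beyond the usual scatter. Compound 2 `NS(=O)(=O)c1ccc(N2N=C(c3ccc(OCc4ccccc4)cc3)CC2c2ccccc2)cc1` is reported only as a limit, > 100000 nM.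

Compound 4 `Cc1cccc(C2CC(c3ccc(Oc4ccccc4)cc3)=NN2c2ccc(S(N)(=O)=O)cc2)c1` differs from compound 3 by one small change: methyl in place of hydrogen on an aromatic carbon. This is methyl in place of hydrogen on an aromatic carbon, meta to a large group, so phenyl becomes 3-methylphenyl.

For the measured compounds named here, only one measured step offers any guidance: an at least 1.1-fold lower number from compound 2 to compound 3 (0.07 log units; that floor lies within the scatter). It places phenyl in place of benzyl on an oxygen on an aromatic ring, which is a different change from the new one. On these data alone, its floor lies within the scatter, and it starts from a limit, so its true size is unknown. Going by the values given here, no measured step adds a methyl. With that single step as the guide, no shift beyond the scatter is expected in this assay. The expected step is a 1.1-fold lower number from compound 3 to compound 4 (0.05 log units; within the scatter). For compound 4 the estimated value is 75000 nM, with an expected range from 35000 nM to 100000 nM.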

Compound 4, half-maximal cytotoxic concentration: 81000 nM
Compound 4: middle estimate off by 1.1-fold (0.03 log units), on the low side; measured number inside the range.
By their numbers in this assay, from the lowest: compound 1; then compounds 4 and 3 (each within the scatter of the next). At a limit, above all of these: compound 2.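

In this assay the new step is a 1.0-fold lower number from compound 3 to compound 4 (0.02 log units; within the scatter), so turning phenyl into 3-methylphenyl leaves the read-out within the usual scatter. For the compounds shown here, this is the first measured step that adds a methyl, and unlike the earlier step, which changed the group on the oxygen and started from a limit, it joins two exact numbers, so its size can be read directly. For this one pair, the aromatic ring carrying the change takes a methyl with no shift beyond the scatter, although a single pair sets no pattern for other groups or other compounds.

On these data alone, it remains open how this place would respond to a group unlike methyl, such as an amine, a carboxylic acid or a longer chain, any of which could give a step beyond the scatter or none at all. A group that raised the number far enough could also stop giving an exact value, since the scale in this series already ends in a limit for one compound: the limit of > 100000 nM in this assay, at which 1 of the 4 values shown sits.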